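A few compounds are considered here, and "the series" means these few. Any claim that something is new, unique, unknown or untested is made for them only; others in the source may bear on it.

Measured so far, in a functional assay on HT-1080 cells (Homo sapiens) for antiproliferative activity, read by sulforhodamine B assay, with a stated time of 48 h; a higher number here means a weaker inhibitor, a lower number a stronger inhibitor:
compound 1 `CC(C)c1ccccc1OS(=O)(=O)c1ccc(NC(=O)C(C)(C)C)cc1`: 11000 nM
compound 2 `CC(C)c1ccccc1OS(=O)(=O)c1ccc(NC(=O)CCCl)cc1`: 6500 nM

The only step between them, a 1.7-fold lower number from compound 1 to compound 2 (0.23 log units; within the scatter), is within the scatter, so compound 1 and compound 2 are not separated on the numbers shown; compound 2 merely carries the lower of the two figures.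

Compound 3 `CCNC(=O)Nc1ccc(S(=O)(=O)Oc2ccccc2C(C)C)cc1` differs from compound 2 at one place: ethylamino in place of 2-chloroethyl on a carbonyl carbon. Within the data shown here, no measured pair shows this exchange; the one step in hand, a 1.7-fold lower number from compound 1 to compound 2 (0.23 log units; within the scatter), concerns a different substituent at the same carbonyl carbon and gave no change beyond the scatter. There is therefore no basis in this assay for expecting a move in either direction beyond the scatter, and the expected step is a 1.2-fold higher number from compound 2 to compound 3 (0.09 log units; within the scatter).

On that basis compound 3 is estimated at 8000 nM, with a range of 2500 nM to 25000 nM.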

Compound 3, half-maximal inhibitory concentration: 250 nM
Compound 3: the middle estimate sits 32-fold (1.51 log units) above what was measured; the measured number lies below the stated range.
By their numbers in this assay, from the lowest: compound 3; then compounds 2 and 1 (each within the scatter of the next).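

In this assay, ethylamino on this carbonyl carbon gives a 26-fold lower number from compound 2 to compound 3 (1.41 log units; beyond the scatter) in place of 2-chloroethyl and a 44-fold lower number from compound 1 to compound 3 (1.64 log units; beyond the scatter) in place of tert-butyl. The position therefore responds strongly to the substituent, which the exchange between tert-butyl and 2-chloroethyl in compound 1 and compound 2 did not show, and the change that does so turns a (2-chloroethyl)carbonyl into an ethylcarbamoyl, adding one hydrogen-bond donor by count. No supporting data bear on the origin of this gain.

The compounds shown leave open whether the ethyl part matters, since methylamino or a longer alkylamino chain on this carbonyl carbon would be needed to test it. As far as these compounds go, whether the hydrogen on the entering nitrogen is needed also stays open, a question that dimethylamino at the same place would address.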